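Removing One Fluoro Group from Compound 1

The source may report more compounds than this note shows. Statements on the series, on what has been measured and on what is new or still open speak of the compounds shown alone.

Measured so far in a functional assay on MCF7 cells (Homo sapiens) for antiproliferative activity, read by MTT assay, with a stated time of 72 h; on this read-out lower numbers stand for stronger inhibition and higher numbers for weaker inhibition:
- compound 1 `COc1ccc(/C=N/NC(=O)Nc2ccc(Oc3ccnc4[nH]ccc34)c(F)c2)c(OC)c1OC`: 134 nM
- compound 2 `COc1cc(/C=N/NC(=O)Nc2ccc(Oc3ccnc4[nH]ccc34)c(F)c2)cc(OC)c1OC`: 21900 nM

Of these two, compound 1 has the lower number and so the stronger inhibition of cell growth. Compound 2 sits far higher, and that gap lies well beyond the usual scatter of repeated measurements. The two values show that compounds of this family can differ widely in this assay.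

The next compound to be tested is compound 3 `COc1ccc(/C=N/NC(=O)Nc2ccc(Oc3ccnc4[nH]ccc34)cc2)c(OC)c1OC`. It is compound 1 with one small edit: hydrogen in place of fluoro on an aromatic carbon. This is hydrogen in place of fluoro on an aromatic carbon of a six-membered aromatic ring of carbon only, ortho to a large group and meta to a large group. Everything else stays the same.

Within the data shown here, no measured pair here shows what this swap does, so the expectation is a cautious one. The expected change is a 1.9-fold higher number from compound 1 to compound 3 (0.29 log units; within the scatter), a modest move towards weaker inhibition, about the size of the usual scatter. For compound 3 the estimated value is 260 nM, with an expected range from 70 nM to 1200 nM.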

Compound 3, half-maximal inhibitory concentration: "not active" (no number reported)
Compound 3 has no reported number here, and the estimate cannot be compared.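

In this assay, among these compounds, compound 3 is reported only as "not active", with no number, so no step from compound 1 to compound 3 can be read. No supporting data bear on this result. The compounds shown leave open how much weaker compound 3 might be than compound 1, and what replacing fluoro with hydrogen does in numbers.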